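Swapping a pyrazole for a triazole on a shared core

This account rests on a few compounds, and the source may have more. Where it says the series, first, only, none or still open, it means among the compounds named here.

Of the compounds shown here, three built on the same core have been measured in a functional assay with Alpha-1A adrenergic receptor (Homo sapiens) as the target, read by calcium flux; a higher number here means a larger maximal response, a lower number a smaller maximal response. Compound 1 `Cn1nccc1-c1ccccc1NCC1=NCCN1` gives 108%, the highest of the three numbers. Compound 2 `Cc1nc(-c2ccccc2NCC2=NCCN2)n(C)n1` gives 98%, which lies within the usual scatter of compound 1, while compound 3 `CCCCn1ncnc1-c1ccccc1NCC1=NCCN1` gives 86%, a gap beyond the scatter. Compound 4 `Cn1ncnc1-c1ccccc1NCC1=NCCN1` has not yet been measured in this assay. It differs from compound 1 in one place: 1-methyl-1H-1,2,4-triazol-5-yl in place of 1-methyl-1H-pyrazol-5-yl on an aromatic carbon. Within the data shown here, no step between two measured compounds isolates this change. The step from compound 1 to compound 4 is expected to be small, if anything downward, giving a number 8 percentage points lower from compound 1 to compound 4 (within the scatter), within the scatter. Compound 4 is therefore estimated at 100%, with a range from 85% to 115%.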

Compound 4, largest response reached (reported as maximal response), in percent of the reference or control that the assay uses: 91%
Compound 4: middle estimate off by 9 percentage points, on the high side; the measured number falls inside the stated range.
By their numbers in this assay, from the lowest: compounds 3, 4, 2 and 1 (each within the scatter of the next, the first and the last beyond it).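

In this assay, among these compounds, the first step to isolate this change, with 1-methyl-1H-1,2,4-triazol-5-yl in place of 1-methyl-1H-pyrazol-5-yl, gives a number 17 percentage points lower from compound 1 to compound 4 (beyond the scatter) and is a modest one. The two changes around the triazole stay small: hydrogen in place of propyl on the chain gives a number 5 percentage points higher from compound 3 to compound 4 (within the scatter) and hydrogen in place of methyl on an aromatic carbon gives a number 7 percentage points lower from compound 2 to compound 4 (within the scatter) within the same series. Nothing available explains the step from pyrazole to triazole. Going by these compounds, how an amine or a carboxylic acid on this ring position would read remains open.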